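The compounds below may be only part of what the source reports. "The series", "measured", "known", "first", "only" and "open" are said of these compounds alone.

In an ADME assay on L02 cells (Homo sapiens) for antiproliferative activity, read by MTT assay, with a stated time of 48 h (on this read-out lower numbers stand for stronger inhibition and higher numbers for weaker inhibition), two compounds with the same core have been measured so far. Within the data shown here, compound 1 `C=CCN(C)C(=O)c1ccc(C(CC)(CC)c2ccc(OCCC(O)(CC)CC)c(C)c2)n1CC` gives 1190 nM and compound 2 `CCOC(=O)CN(C)C(=O)c1ccc(C(CC)(CC)c2ccc(OCCC(O)(CC)CC)c(C)c2)n1CC` gives 1990 nM, so compound 2 stands level with its only measured neighbour, within the scatter of repeat measurements. Compound 3 `CCn1c(C(=O)NC(CC(=O)O)C(=O)OC)ccc1C(CC)(CC)c1ccc(OCCC(O)(CC)CC)c(C)c1` keeps the core but changes the group on a carbonyl carbon: a group of 10 heavy atoms (5 carbon, 1 nitrogen, 4 oxygen; no ring) in place of a group of 8 heavy atoms (5 carbon, 1 nitrogen, 2 oxygen; no ring), on a carbonyl carbon. Among the measured compounds shown here, the one measured step that bears on this is a 1.7-fold higher number from compound 1 to compound 2 (0.22 log units; within the scatter), which also altered the group on that carbonyl carbon. It is a single step and a different swap, so it offers only a loose guide. No clear shift is therefore expected in this assay, though a small drift towards a higher number is possible. The expected change is a 1.3-fold higher number from compound 2 to compound 3 (0.10 log units; within the scatter). For compound 3 the estimated value is 2500 nM, with an expected range from 900 nM to 8000 nM.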

Compound 3, half-maximal inhibitory concentration: 7590 nM
Compound 3: the middle estimate sits 3.0-fold (0.48 log units) below what was measured; low and high end bracket the measured number.
By their numbers in this assay, from the lowest: compounds 1 and 2 (each within the scatter of the next); then compound 3.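

The group on the carbonyl carbon can shift the read-out beyond the scatter in this assay: the earlier step between compounds stayed within it, whereas the numbers now rise, towards weaker inhibition, with a 3.8-fold higher number from compound 2 to compound 3 (0.58 log units; beyond the scatter) and a 6.4-fold higher number from compound 1 to compound 3 (0.80 log units; beyond the scatter). This one swap changes several things at once, since the entering group has 2 hydrogen-bond donors and 3 acceptors, against 0 and 2 in the ((ethoxycarbonyl)methyl)(methyl)amino group, and it is also larger, with 10 heavy atoms against 8. No measurement here links the rise to any one of these features or gives a reason for it. As far as these compounds go, what stays open is which part of the entering group matters: its carboxylic acid, its methyl ester or the amide hydrogen. Placing a primary amide or an amine where the carboxylic acid stands would help to separate these.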